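Series notes: a chloro-to-hydrogen step on the aryl ring

The source may hold more compounds than are shown below. What is called first, only, known or untested is meant among the compounds shown, and "the series" means these compounds.

Measured so far in a physicochemical assay for lipophilicity, in phosphate buffer, measured as octanol-water partition, with a stated time of 24 h; on this read-out higher numbers stand for higher lipophilicity and lower numbers for lower lipophilicity:
compound 1 `O=C(CN1C(=O)c2ccccc2C1=O)NN1C(=O)CSC1c1c(F)cccc1Cl`: 3.79
compound 2 `O=C(CN1C(=O)c2ccccc2C1=O)NN1C(=O)CSC1/C=C/c1ccccc1`: 3.65
compound 3 `O=C(CN1C(=O)c2ccccc2C1=O)NN1C(=O)CSC1c1ccc(Cl)cc1`: 3.21

Compound 3 gives the lowest of the three numbers in this assay; the nearest is compound 2 (a number 0.44 log units lower from compound 2 to compound 3 (beyond the scatter)) and the furthest is compound 1 (a number 0.58 log units lower from compound 1 to compound 3 (beyond the scatter)). Compound 4 `O=C(CN1C(=O)c2ccccc2C1=O)NN1C(=O)CSC1c1ccccc1` differs from compound 3 by hydrogen in place of chloro on an aromatic carbon. Within the data shown here, no measured step removes a halogen from the 4-chlorophenyl; the two steps onto compound 3 only swap one aryl group for another and both moved the number modestly downward. The direction for compound 4 is therefore taken from those, with the size estimated rather than read off: compound 4 is expected to sit lower, a number 0.66 log units lower from compound 3 to compound 4 (beyond the scatter). The value for compound 4 in this assay is estimated at 2.55, between 2.15 and 2.95.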

Compound 4, partition coefficient: 2.23
For compound 4 the middle estimate is 0.32 log units above the measured one; measured number inside the range.
By their numbers in this assay, from the lowest: compound 4; then compound 3; then compounds 2 and 1 (each within the scatter of the next).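

In this assay, compound 4 stands lowest of the four, and hydrogen in place of chloro on the aromatic carbon gives a clear step on its own (a number 0.98 log units lower from compound 3 to compound 4 (beyond the scatter)), while phenyl in place of 2-phenylethenyl (a number 1.42 log units lower from compound 2 to compound 4 (beyond the scatter)) and phenyl in place of 2-chloro-6-fluorophenyl (a number 1.56 log units lower from compound 1 to compound 4 (beyond the scatter)) give larger ones. That single chloro moves the number further than any step among compound 1, compound 2 and compound 3. No evidence at hand speaks to the reason for this.

Going by these compounds, whether a fluoro, a methoxy or an amine on the same aromatic carbon would land nearer compound 3 or compound 4 stays open.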